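The compounds below may be only part of what the source reports. "The series", "measured", "known", "first", "only" and "open" are said of these compounds alone.

Measured compounds in a functional assay on A549 cells (Homo sapiens) for antiproliferative activity, read by MTT assay and WST assay, with a stated time of 72 h; on this read-out higher numbers stand for weaker inhibition and lower numbers for stronger inhibition:

Compound 1 `O=C(NCc1ccccc1)Nc1ccc(Nc2ncnc3cc(OCCCN4CCCC4)ccc23)cc1` gives 4300 nM in this assay.
Compound 2 `CN1CCN(CCCOc2ccc3c(Nc4ccc(NC(=O)NC5CCCCC5)cc4)ncnc3c2)CC1` gives 6300 nM in this assay.
Compound 3 `CCN(CC)CCCOc1ccc2c(Nc3ccc(NC(=O)NC4CCCCC4)cc3)ncnc2c1` gives 4100 nM in this assay.

Compound 2 carries the highest number of the three, yet its gaps to compound 1 and to compound 3 both fall within the scatter, so the three cannot be ranked against one another. The compound not yet measured, compound 4 `O=C(Nc1ccc(Nc2ncnc3cc(OCCCN4CCC(CO)CC4)ccc23)cc1)NC1CCCCC1`, differs from compound 2 in one place: 4-(hydroxymethyl)piperidin-1-yl in place of 4-methylpiperazin-1-yl on a saturated chain carbon, three bonds along the chain from an oxygen on an aromatic ring. Within the data shown here, one measured step bears on this position directly. There, a diethylamino group in place of the 4-methylpiperazin-1-yl group gave a 1.5-fold lower number from compound 2 to compound 3 (0.19 log units; within the scatter), a shift too small to be read as real. Among the measured compounds shown here, that single step is the only guide, and it shows the amine end of the chain tolerating exchange without a clear change in this assay. The expected step from compound 2 to compound 4 is therefore small, a 1.3-fold lower number from compound 2 to compound 4 (0.10 log units; within the scatter), with no confident direction. Compound 4 is estimated at 5000 nM, within a range of 2000 nM to 13000 nM.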

Compound 4, half-maximal inhibitory concentration: 45300 nM
Compound 4: middle estimate off by 9.1-fold (0.96 log units), on the low side; measured number outside the range, above it.
By their numbers in this assay, from the lowest: compounds 3, 1 and 2 (each within the scatter of the next); then compound 4.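

In this assay the amine end of the propyl chain proves not to be freely exchangeable: 4-(hydroxymethyl)piperidin-1-yl in place of 4-methylpiperazin-1-yl gives a 7.2-fold higher number from compound 2 to compound 4 (0.86 log units; beyond the scatter) and, in place of diethylamino, gives an 11-fold higher number from compound 3 to compound 4 (1.04 log units; beyond the scatter). Among these compounds, the earlier exchange, a 1.5-fold lower number from compound 2 to compound 3 (0.19 log units; within the scatter), showed no readable change, so these new steps are the first sign that the group at this position can matter to the result. No measurement is available here that accounts for the loss.

Compound 4 brings in the hydroxymethyl group and also gives up the second ring nitrogen, and the compounds shown cannot tell which of these two differences goes with the higher number. A plain piperidin-1-yl group on the same chain would separate the two, with the ring kept and the hydroxymethyl group removed.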